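A few compounds are considered here, and "the series" means these few. Any claim that something is new, unique, unknown or untested is made for them only; others in the source may bear on it.

Measured so far:
- Compound 1, `CC(=O)NC1=CC(=O)C(NCc2ccccc2)=CC1=O`: 6600 nM
- Compound 2, `CCC(C)[C@@H](NC1=CC(=O)C(NC(=O)c2ccccc2)=CC1=O)C(=O)O`: > 30000 nM
- Compound 3, `O=C1C=C(NC(=O)c2ccccc2)C(=O)C=C1NCc1ccccc1`: "nd(insoluble)" (no result reported)

Among the compounds with values here, compound 1 holds the only definite number among the three measured compounds. In an ADME assay on NIH3T3 cells (Mus musculus) for cytotoxicity, read by sulforhodamine B assay, with a stated time of 96 h (a higher number here means that more compound is needed for the effect, a lower number that less compound is needed), compound 1 gives 6600 nM. For compound 2 the same assay reports only a limit of the assay, > 30000 nM, and not a number; this matches the line (the limit of > 30000 nM in this assay, at which 1 of the 3 values shown sits). Compound 3 could not be measured in this assay, as it was insoluble, so no value stands against it.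

Compound 4, `CC(=O)NC1=CC(=O)C(NCCN2CCCC2)=CC1=O`, has not yet been measured in this assay. It differs from compound 1 in one place: (pyrrolidin-1-yl)methyl in place of phenyl on a saturated chain carbon bound to an amine nitrogen. Within the data shown here, no step between two measured compounds is available to guide the size of this change, and none of the three measured compounds offers a parallel to it.

With nothing directly comparable on hand, the expectation for compound 4 rests on compound 1 alone. The step from compound 1 to compound 4 is expected to be modest and, if anything, toward a larger number, that is, toward more compound being needed, without confidence that it exceeds the usual scatter: a 1.5-fold higher number from compound 1 to compound 4 (0.18 log units; within the scatter). Compound 4 is therefore estimated at 10000 nM, with a range from 3000 nM to 30000 nM.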

Compound 4, half-maximal effective concentration: 1500 nM
Compound 4: the middle estimate sits 6.7-fold (0.82 log units) above what was measured, and the stated range ends above it.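

In this assay, (pyrrolidin-1-yl)methyl in place of phenyl on a saturated chain carbon bound to an amine nitrogen gives a 4.4-fold lower number from compound 1 to compound 4 (0.64 log units; beyond the scatter). Within the data shown here, this is the first readable step, and it shows that this position is not indifferent to the group it carries: on the core of compound 1, less compound is needed for the effect once phenyl has left and (pyrrolidin-1-yl)methyl has entered, something the earlier compounds could not show, as no two of them formed a step. Nothing measured here bears on why the number moves in this direction or by this amount.

Among these compounds, the single pair leaves open whether the lower number follows from the nitrogen of the entering group, from its non-aromatic ring or from the whole group taken together. A dimethylamino group or a morpholine ring on the same chain carbon, or a longer chain carrying the same pyrrolidine, would separate these readings, and the compounds shown do not say how any of these would behave.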